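The compounds below may be only part of what the source reports. "The series", "measured", "known", "first", "only" and "open" are said of these compounds alone.

Compound 1, `Cc1cc(=O)n(CCC(=N)S)nc1-c1ccccc1`, was tested in a functional assay on the whole organism (stomach) with Rattus norvegicus as the target; on this read-out lower numbers stand for an effect already at smaller amounts and higher numbers for an effect only at larger amounts of compound. In this assay compound 1 gives only > 100 mg/kg, which is a limit of the assay rather than a number. Compound 2, `O=c1cccnn1CCC(=S)N1CCCC1`, likewise reaches only a limit in this assay, > 100 mg/kg. Compound 1 thus stands at the limit of > 100 mg/kg in this assay, at which 2 of the 2 values shown sit. Compound 3, `N=C(S)CCn1nc(-c2ccccc2)ccc1=O`, differs from compound 1 by hydrogen in place of methyl on an aromatic carbon. Among the measured compounds shown here, no measured pair shows what such a change does in this assay. The change is expected to bring a step that the limit leaves unreadable from compound 1 to compound 3, nothing beyond the usual scatter. Compound 3 is therefore estimated at 150 mg/kg, between 60 mg/kg and 400 mg/kg.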

Compound 3, dose for half-maximal effect: 87.3 mg/kg
Beside the measured number, compound 3's estimate is 1.7-fold (0.24 log units) above it; the range from low to high includes it.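

Replacing methyl with hydrogen on this aromatic carbon, ortho to a phenyl group, brings an at least 1.1-fold lower number from compound 1 to compound 3 (0.05 log units; that floor lies within the scatter). Among the compounds shown here, compound 3 is the first compound here to give a real number rather than a limit in this assay. Only a floor for the step can be read, so its true size stays unknown: the limit of > 100 mg/kg in this assay, at which 2 of the 3 values shown sit.

The compounds shown leave open how an ethyl group, a methoxy group or an amine on this same carbon would read in this assay. They also leave open whether removing the phenyl group would change the value of compound 3.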